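Trimethoxybenzyl on the triazole of an amide series

The source may report more compounds than this note shows. Statements on the series, on what has been measured and on what is new or still open speak of the compounds shown alone.

In a functional assay on MCF7 cells (Homo sapiens) for antiproliferative activity, read by sulforhodamine B assay, with a stated time of 48 h (on this read-out lower numbers stand for stronger inhibition of growth and higher numbers for weaker inhibition of growth), compound 1 `COc1cc(Cn2cc(CNC(=O)c3cn(-c4ccccc4)nc3-c3ccc(Cl)cc3)nn2)cc(OC)c1OC` gives 2500 nM. Compound 2 `COc1ccc(-c2nn(-c3ccccc3)cc2C(=O)NCc2cn(Cc3ccc(Cl)cc3)nn2)cc1`, which carries a chlorobenzyl group on the triazole instead, gives 2900 nM in this assay. Compound 3 `COc1ccc(-c2nn(-c3ccccc3)cc2C(=O)NCc2cn(Cc3ccc(C(F)(F)F)cc3)nn2)cc1` reaches only a limit in this assay, namely > 100000 nM. That limit is the limit of > 100000 nM in this assay, at which 1 of the 3 values shown sits. Among the measured compounds shown here, the single measured step, an at least 34-fold higher number from compound 2 to compound 3 (1.53 log units; beyond the scatter), is large and concerns this same benzyl position. Compound 4 `COc1ccc(-c2nn(-c3ccccc3)cc2C(=O)NCc2cn(Cc3cc(OC)c(OC)c(OC)c3)nn2)cc1` differs from compound 3 by 3,4,5-trimethoxyphenyl in place of 4-(trifluoromethyl)phenyl on a saturated chain carbon bound to an aromatic nitrogen. For the measured compounds named here, the entering group is the one compound 1 bears at the corresponding place, and compound 1 gave 2500 nM in this assay. Compound 4 is therefore expected to return to that region, an estimated 3000 nM with a range of 800 nM to 15000 nM, a step of an at least 33-fold lower number from compound 3 to compound 4 (1.52 log units; beyond the scatter).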

Compound 4, concentration for 50% growth inhibition: 7600 nM
Compound 4: middle estimate off by 2.5-fold (0.40 log units), on the low side, within the range that was stated.
By their numbers in this assay, from the lowest: compounds 1 and 2 (each within the scatter of the next); then compound 4. At a limit, above all of these: compound 3.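

Placing 3,4,5-trimethoxyphenyl on the saturated chain carbon bound to an aromatic nitrogen brings measurable growth inhibition back, with an at least 13-fold lower number from compound 3 to compound 4 (1.11 log units; beyond the scatter), though this step rests on a limit for compound 3: the limit of > 100000 nM in this assay, at which 1 of the 4 values shown sits. The same group does not match 4-chlorophenyl, with a 2.6-fold higher number from compound 2 to compound 4 (0.42 log units; beyond the scatter). The other site also matters, since methoxy in place of chloro on an aromatic carbon gives a 3.0-fold higher number from compound 1 to compound 4 (0.48 log units; beyond the scatter).

As far as these compounds go, whether a carboxylic acid or an amine at this position would retain activity remains open. So does why trifluoromethyl and chloro differ so sharply.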